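A few compounds are considered here, and "the series" means these few. Any claim that something is new, unique, unknown or untested is made for them only; others in the source may bear on it.

Compound 1 `C/C=C1/[C@H](O[C@@H]2O[C@H](COC(C)=O)[C@@H](OC(C)=O)[C@H](OC(C)=O)[C@H]2OC(C)=O)OC=C(C(=O)OC)[C@H]1CC(=O)OCCC`: 6600 nM
Compound 2 `C/C=C1/[C@H](O[C@@H]2O[C@H](COC(C)=O)[C@@H](OC(C)=O)[C@H](OC(C)=O)[C@H]2OC(C)=O)OC=C(C(=O)O)[C@H]1CC(=O)OC`: > 20000 nM

For the measured compounds named here, compound 1 stands as the only measured number here, giving 6600 nM in a functional assay on SK-BR-3 cells (Homo sapiens) for antiproliferative activity, read by MTT assay, with a stated time of 72 h; on this read-out lower numbers stand for stronger inhibition and higher numbers for weaker inhibition. For compound 2 the reported value is a limit of the assay and not a number: the limit of > 20000 nM in this assay, at which 1 of the 2 values shown sits. Compound 3 `C=CCOC(=O)C[C@@H]1C(C(=O)OC)=CO[C@@H](O[C@@H]2O[C@H](COC(C)=O)[C@@H](OC(C)=O)[C@H](OC(C)=O)[C@H]2OC(C)=O)/C1=C/C` differs from compound 1 by vinyl in place of ethyl on a saturated chain carbon bound to an oxygen next to a carbonyl group. Going by the values given here, with no step between measured compounds to lean on, the expected step of a 1.1-fold lower number from compound 1 to compound 3 (0.04 log units; within the scatter) in this assay is small, in neither direction beyond the usual scatter. Compound 3 is therefore expected to give 6000 nM, somewhere within 2500 nM to 15000 nM.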

Compound 3, half-maximal inhibitory concentration: > 20000 nM
Compound 3 ended at the assay's limit (the forecaster's own chance of this, stated with the estimate: 15%); middle value at least 3.3-fold (0.52 log units) away from the limit.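

In this assay, this position proves sensitive to a small edit: replacing ethyl with vinyl on a saturated chain carbon bound to an oxygen next to a carbonyl group gives an at least 3.0-fold higher number from compound 1 to compound 3 (0.48 log units; beyond the scatter). Both groups have 2 heavy atoms, so the added double bond alone separates these two compounds. Compound 3 sits at a limit of the assay, not at a number: the limit of > 20000 nM in this assay, at which 2 of the 3 values shown sit.

As far as these compounds go, whether a butyl chain, a propargyl group or a benzyl group at this place would keep the activity of compound 1 remains open. So does the effect of an amide in place of this ester.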